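Replacing propa-1,2-dien-1-yl with 2-phenylethenyl on the shared core

A few compounds are considered here, and "the series" means these few. Any claim that something is new, unique, unknown or untested is made for them only; others in the source may bear on it.

Measured so far in a functional assay on aorta (Rattus norvegicus, strain Sprague-Dawley) for inhibition (a lower number here means that less compound is needed, a higher number that more compound is needed for the effect), for two compounds
- compound 1 `CCCOc1cc2c(c3c1C[C@@H]1[C@@H](C)CO[C@]1(C)O3)C[C@@H]1[C@@H](C)CO[C@]1(C)O2` gives 77000 nM
- compound 2 `C=C=CCOc1cc2c(c3c1C[C@@H]1[C@@H](C)CO[C@]1(C)O3)C[C@@H]1[C@@H](C)CO[C@]1(C)O2` gives 11000 nM

For the measured compounds named here, of these two numbers, the lower belongs to compound 2 (11000 nM), and the only comparison available is compound 1, which has the higher number. The next compound, compound 3 `C[C@H]1CO[C@]2(C)Oc3cc(OC/C=C/c4ccccc4)c4c(c3C[C@H]12)O[C@@]1(C)OC[C@H](C)[C@H]1C4`, keeps the shared core and differs from compound 2 in one group (2-phenylethenyl in place of propa-1,2-dien-1-yl on a saturated chain carbon bound to an oxygen on an aromatic ring). There, 2-phenylethenyl stands in place of propa-1,2-dien-1-yl on a saturated chain carbon bound to an oxygen on an aromatic ring. Going by the values given here, the single measured step at this place (a 7.0-fold lower number from compound 1 to compound 2 (0.85 log units; beyond the scatter)) put propa-1,2-dien-1-yl in place of ethyl and was modest. Among the compounds with values here, no measured compound carries an aromatic ring on this chain, so that step offers only a loose guide. In this assay a small move toward a lower number is expected, perhaps none beyond the scatter. The estimated step is a 1.6-fold lower number from compound 2 to compound 3 (0.20 log units; within the scatter) and rests on this one precedent alone. The estimate for compound 3 is expected to be near the value given here (7000 nM, range 1500 nM to 35000 nM).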

Compound 3, half-maximal effective concentration: > 200000 nM
Compound 3 ended at the assay's limit (the forecaster's own chance of this, stated with the estimate: 15%); middle value at least 28-fold (1.45 log units) from the limit.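

In this assay compound 3 reads as a limit and not as a number: the limit of > 200000 nM in this assay, at which 1 of the 3 values shown sits. The earlier step, a 7.0-fold lower number from compound 1 to compound 2 (0.85 log units; beyond the scatter), had shown only a move toward a lower number at this place, whereas 2-phenylethenyl in place of propa-1,2-dien-1-yl reverses that direction and gives an at least 18-fold higher number from compound 2 to compound 3 (1.25 log units; beyond the scatter). Set against the ethyl of the first compound in the series, the same group gives an at least 2.5-fold higher number from compound 1 to compound 3 (0.41 log units; beyond the scatter), so this place on a saturated chain carbon bound to an oxygen on an aromatic ring does not accept every replacement, and the step to 2-phenylethenyl carries the number past both earlier values.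

The three compounds leave open whether the six-membered aromatic ring itself or simply the larger group of 8 heavy atoms goes with this rise, since a longer chain without a ring, such as hexyl, or a saturated 2-phenylethyl group would be needed to separate the two. Going by these compounds, how far compound 3 lies past its limit also remains unknown, and so does the full size of both new steps.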